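Trifluoromethyl on the Benzylidene Phenyl of Compound 1

The compounds below may be only part of what the source reports. "The series", "measured", "known", "first", "only" and "open" are said of these compounds alone.

Measured compounds:
compound 1, `O=C1/C(=C\c2ccccc2)c2c(ncn2COCc2ccccc2)CCN1Cc1ccccc1`, 20400 nM
compound 2, `Cc1ccccc1CN1CCc2ncn(COCc3ccccc3)c2/C(=C/c2ccccc2)C1=O`, 31300 nM

Of the compounds shown here, two have been tested in a functional assay on BGC-823 cells (Homo sapiens) for inhibition, read by MTT assay, with a stated time of 72 h; a higher number here means a weaker inhibitor, a lower number a stronger inhibitor. Compound 1 has the lower of the two numbers, and compound 2 sits close to it: a 1.5-fold higher number from compound 1 to compound 2 (0.19 log units; within the scatter), so the two cannot be told apart. Compound 3, `O=C1/C(=C\c2ccc(C(F)(F)F)cc2)c2c(ncn2COCc2ccccc2)CCN1Cc1ccccc1`, has not yet been measured. It differs from compound 1 by trifluoromethyl in place of hydrogen on an aromatic carbon.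

Going by the values given here, no measured step touches this part of the molecule; the only step known, from compound 1 to compound 2, changes a different ring and stays within the scatter. There is therefore nothing to suggest a shift in either direction, and the author expects compound 3 to come out near compound 1, with a 1.0-fold lower number from compound 1 to compound 3 (0.01 log units; within the scatter). The estimate for compound 3 in this assay is 20000 nM, with a range from 7000 nM to 55000 nM.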

Compound 3, half-maximal inhibitory concentration: 42600 nM
Compound 3: middle estimate off by 2.1-fold (0.33 log units), on the low side; the range from low to high includes it.
By their numbers in this assay, from the lowest: compounds 1, 2 and 3 (each within the scatter of the next, the first and the last beyond it).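

In this assay, the phenyl that takes the new group responds to substitution: a 2.1-fold higher number from compound 1 to compound 3 (0.32 log units; beyond the scatter), a modest step towards weaker inhibition. Going by these compounds alone, the only earlier step, a 1.5-fold higher number from compound 1 to compound 2 (0.19 log units; within the scatter), lay in a different ring and stayed within the scatter, so this is the first change to move the number beyond it, and it shows that trifluoromethyl para to a large group brings no gain here. No measurement available accounts for the shift.

The compounds shown leave open whether this loss is particular to trifluoromethyl or would also follow from a fluorine atom, a methoxy group or an amine on the same carbon. They also leave open whether the same group would have a similar effect elsewhere on this ring.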